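A few compounds are considered here, and "the series" means these few. Any claim that something is new, unique, unknown or untested is made for them only; others in the source may bear on it.

Working notes on the series, read in an ADME assay on H1-HeLa cells (Homo sapiens) for cytotoxicity, read by MTT assay, with a stated time of 3 days; on this read-out lower numbers stand for higher toxicity in this test and higher numbers for lower toxicity in this test.

Compound 1 `CCOC(=O)c1cc2ccc(Oc3ccnc(C(=O)NC)c3)cc2s1` gives only a limit of the assay, > 100000 nM. Compound 2 `CNC(=O)c1cc(Oc2ccc3cc(C(=O)OC)sc3c2)ccn1` likewise gives only a limit, > 100000 nM. Going by the values given here, compound 3 `CNC(=O)c1cc(Oc2ccc3ccc(C(=O)OC(C)C)cc3c2)ccn1` is the one compound with a number, 13800 nM; how its core differs from the core of compound 2 is not broken down here.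

One change occurs twice among these compounds. From compound 2 to compound 1 it is methyl in place of hydrogen on a saturated chain carbon bound to an oxygen next to a carbonyl group, and the step that the two limits leave unreadable from compound 2 to compound 1 cannot be sized because of the limit of > 100000 nM in this assay, at which 2 of the 3 values shown sit. From compound 3 to compound 4 `CCC(C)OC(=O)c1ccc2ccc(Oc3ccnc(C(=O)NC)c3)cc2c1` it is methyl in place of hydrogen on a saturated chain carbon, two bonds along the chain from an oxygen next to a carbonyl group; the two place lines differ in that the first methyl sits on a carbon bound to the oxygen and the second two bonds along the chain from it, so this is the same kind of change, not the same one.

With the earlier step unreadable, no direction is supported by a measured step; compound 4 is therefore expected to stay close to compound 3, a step of about a 1.3-fold lower number from compound 3 to compound 4 (0.10 log units; within the scatter). The estimate for compound 4 is 11000 nM, spanning 4000 nM to 35000 nM.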

Compound 4, half-maximal cytotoxic concentration: 16000 nM
For compound 4 the middle estimate is 1.5-fold (0.16 log units) below the measured one, within the range that was stated.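

In this assay the new step is a 1.2-fold higher number from compound 3 to compound 4 (0.06 log units; within the scatter), so on the core of compound 3 this methyl leaves the two values indistinguishable. The related step on the other core, from compound 2 to compound 1, cannot be read because each of those two compounds gives only a limit of the assay: the limit of > 100000 nM in this assay, at which 2 of the 4 values shown sit.

The series therefore offers one readable step and no second one to set it against, and the two methyls sit at different places on the chain, so nothing here shows whether the change carries from one core to another.

As far as these compounds go, whether a longer chain on the ester oxygen, or a carboxylic acid in place of the ester, would shift the read-out on either core remains open. Also open is whether the two cores differ at all when they carry one and the same ester group, since no such pair is among the compounds shown.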